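The source may report more compounds than this note shows. Statements on the series, on what has been measured and on what is new or still open speak of the compounds shown alone.

Compound 3 `COc1ccc2[nH]c(C(=O)N3CC(=O)N(Cc4ccccc4)[C@@H](CN4[C@H](C)COC[C@@H]4C)C3)cc2c1` is one of three compounds that have been tested in a physicochemical assay for solubility, read by spectrophotometry, in phosphate buffer, with a stated time of 2 h, at pH 7.4 (on this read-out higher numbers stand for higher solubility and lower numbers for lower solubility), together with compound 1 `COc1ccc2[nH]c(C(=O)N3CC(=O)N(Cc4ccccc4)[C@@H](Cc4ccccn4)C3)cc2c1` and compound 2 `COc1ccc2[nH]c(C(=O)N3CC(=O)N(Cc4ccccc4)[C@@H](N4[C@H](C)CCC[C@@H]4C)C3)cc2c1`. In this assay compound 1 gives only a limit of the assay, > 100000 nM. In this assay compound 2 gives 100000 nM. In this assay compound 3 likewise gives only a limit of the assay, > 100000 nM. As far as these compounds go, compound 3 therefore stands at the limit where two of the three values sit (the limit of > 100000 nM in this assay, at which 2 of the 3 values shown sit), and none of the steps among the three can be sized: a number no higher from compound 1 to compound 2 (the limit leaves the size open), a step that the two limits leave unreadable from compound 1 to compound 3 and a number no lower from compound 2 to compound 3 (the limit leaves the size open) all remain open. Compound 4 `COc1ccc2[nH]c(C(=O)N3CC(=O)N(Cc4ccccc4)[C@@H](CN4CCc5ccccc5C4)C3)cc2c1` differs from compound 3 in one place: 1,2,3,4-tetrahydroisoquinolin-2-yl in place of 3,5-dimethylmorpholin-4-yl on a saturated chain carbon bound to a saturated ring carbon. Within the data shown here, none of the measured steps involves a 1,2,3,4-tetrahydroisoquinolin-2-yl group, so no measured step speaks to this change directly; the measurements show only that all three compounds sit at or beside the limit. Compound 4 is therefore expected to fall somewhat below the limit, a step of an at least 2.0-fold lower number from compound 3 to compound 4 (0.30 log units; that floor lies within the scatter) downward, though the limit on compound 3 leaves the true size open. Compound 4 is estimated at 50000 nM, within a range from 10000 nM to 100000 nM.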

Compound 4, solubility: 9000 nM
For compound 4 the middle estimate is 5.6-fold (0.74 log units) above the measured one; the whole stated range lies above it.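

In this assay, among these compounds, the change on a saturated chain carbon bound to a saturated ring carbon gives the first step here that can be sized, and it is large: 1,2,3,4-tetrahydroisoquinolin-2-yl in place of 3,5-dimethylmorpholin-4-yl brings (an at least 11-fold lower number from compound 3 to compound 4 (1.04 log units; beyond the scatter)). The earlier compounds had shown no readable movement at this place, whereas compound 4 also stands clearly apart from the other two (an 11-fold lower number from compound 2 to compound 4 (1.05 log units; beyond the scatter)) and (an at least 11-fold lower number from compound 1 to compound 4 (1.04 log units; beyond the scatter)). The steps among compound 1, compound 2 and compound 3 still cannot be read, and the steps to compound 4 from compound 1 and compound 3 start from a limit of the assay, so that only a lower bound on their size is known: the limit of > 100000 nM in this assay, at which 2 of the 4 values shown sit.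

As far as these compounds go, whether the lower number goes with the six-membered aromatic ring of carbon only, or with the loss of the ring oxygen and the two defined stereocentres, stays open. An unsubstituted morpholin-4-yl or piperidin-1-yl group, or an open-chain benzylamine, on the same chain carbon would be needed to tell these apart.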